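Dropping one chloro from a dichloropurine cytotoxic agent

The compounds below may be only part of what the source reports. "The series", "measured", "known", "first", "only" and "open" are said of these compounds alone.

Among the measured compounds shown here, compound 1 `ClCc1ccc(Cn2cnc3nc(Cl)nc(Cl)c32)cc1` is the stronger of the two compounds measured so far. In a functional assay on TK-10 cells (Homo sapiens) for cytotoxicity, read by sulforhodamine B assay, with a stated time of 48 h (on this read-out higher numbers stand for weaker inhibition of growth and lower numbers for stronger inhibition of growth), compound 1 gives 290 nM, the lowest value of the pair. Compound 2 `ClCc1cccc(Cn2cnc3c(Cl)nc(Cl)nc32)c1`, which carries its substituents in a different arrangement, is the weaker of the two; in this assay compound 2 gives 3980 nM, a clearly higher number that lies beyond the usual scatter. Compound 3 `ClCc1ccc(Cn2cnc3ncnc(Cl)c32)cc1` has not yet been measured. It differs from compound 1 in one place: hydrogen in place of chloro on an aromatic carbon. For the measured compounds named here, no measured pair shows this exact change, so its effect is unknown; the remaining chloro group and the chloromethylbenzyl arm are kept. A modest move toward weaker growth inhibition is expected, since one of the two reactive-looking chloro groups is gone, though a step within the scatter cannot be excluded. Compound 3 is expected to give 700 nM in this assay, within a range from 200 nM to 2500 nM, a step of a 2.4-fold higher number from compound 1 to compound 3 (0.38 log units; beyond the scatter) that is estimated, not measured.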

Compound 3, concentration for total growth inhibition: 2950 nM
Beside the measured number, compound 3's estimate is 4.2-fold (0.62 log units) below it; measured number outside the range, above it.
By their numbers in this assay, from the lowest: compound 1; then compounds 3 and 2 (each within the scatter of the next).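

In this assay, replacing one chloro with hydrogen gives a 10-fold higher number from compound 1 to compound 3 (1.01 log units; beyond the scatter). This is the first change in one place among these compounds, and it shows that growth inhibition is sensitive to what sits on this aromatic carbon between two ring nitrogen atoms, even with the remaining chloro group and the chloromethylbenzyl arm kept. Nothing available bears on the cause of this large step.

Whether chloro is specifically needed at this carbon remains open, as the compounds shown do not reveal how an amine, a methoxy group or a fluoro would compare there with hydrogen. On these data alone, what the remaining chloro group, meta to this carbon, contributes to growth inhibition by itself also remains open.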